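Sulfonamide chain shape in the hepatoma antiproliferative series

The source may report more compounds than this note shows. Statements on the series, on what has been measured and on what is new or still open speak of the compounds shown alone.

Three compounds of the shared core carry numbers in a functional assay on Huh-7 cells (Homo sapiens) for antiproliferative activity, read by CCK-8 assay, with a stated time of 72 h; a lower number here means a stronger inhibitor of growth, a higher number a weaker inhibitor of growth. Compound 1 `CCC1C(=O)N(C)c2cnc(-n3ccc4cc(C(N)=O)ccc43)nc2N1c1ccn(C)n1` bears a carboxamide on its fused bicyclic substituent; in this assay compound 1 gives "not active" (no number reported). Compound 2 `CCC1C(=O)N(C)c2cnc(Nc3ccc(S(=O)(=O)NCCCO)cc3)nc2N1c1ccn(C)n1` carries a hydroxypropylsulfamoyl group on the anilino ring; in this assay compound 2 gives "not active" (no number reported). Within the data shown here, compound 3 `CCC1C(=O)N(C)c2cnc(Nc3ccc(S(=O)(=O)NCC(C)C)cc3)nc2N1c1ccn(C)n1`, with an isobutylsulfamoyl group on the same anilino ring, is the only member with a reported number: in this assay compound 3 gives 8520 nM. Compound 3 therefore stands as the sole quantified point of the set; the other two entries carry no number, so no ranking among the three can be drawn.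

Compound 4 `CCCCNS(=O)(=O)c1ccc(Nc2ncc3c(n2)N(c2ccn(C)n2)C(CC)C(=O)N3C)cc1` is the next member to be measured. It differs from compound 3 only in the sulfonamide substituent: propyl in place of isopropyl on a saturated chain carbon bound to a sulfonamide nitrogen. Among the measured compounds shown here, no step between measured compounds of this kind is available, so the expectation rests on compound 3 alone. Because compound 3 gives 8520 nM, the step of a 1.1-fold lower number from compound 3 to compound 4 (0.06 log units; within the scatter) is expected to stay within the scatter of the assay, with no clear direction. Compound 4 is accordingly estimated at 7500 nM, with a range from 2500 nM to 25000 nM.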

Compound 4, concentration for 50% growth inhibition: 3750 nM
The estimate for compound 4 lay 2.0-fold (0.30 log units) above the measured number, and the stated range covers the measured number.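

Read in this assay, propyl in place of isopropyl on a saturated chain carbon bound to a sulfonamide nitrogen gives a 2.3-fold lower number from compound 3 to compound 4 (0.36 log units; beyond the scatter), a modest change and the first step that can be read in this series. The two compounds hold the same atoms joined differently, so within this pair the isobutylsulfamoyl and butylsulfamoyl groups differ only in how the chain is connected, and that difference alone is enough to move the number beyond the scatter. No measurement at hand explains the step, which remains an observation on a single pair.

Steps involving the other two entries cannot be read: compound 1 gives "not active" (no number reported) and compound 2, with its hydroxypropylsulfamoyl group, gives "not active" (no number reported). Going by these compounds, whether the lower number continues with a longer chain such as pentyl, or how a cyclopropylmethyl group or a chain ending in an amine or a carboxylic acid would read at the same place, remains open.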